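A few compounds are considered here, and "the series" means these few. Any claim that something is new, unique, unknown or untested is made for them only; others in the source may bear on it.

Compounds measured so far:
compound 1 `C/C(=N\NC(=S)Nc1cccc(F)c1)c1ccccn1`: 12 nM
compound 2 `CC(=NNC(=S)Nc1cccc(F)c1)c1ccccn1`: 12 nM
compound 3 `CC(=NNC(=S)Nc1ccc([N+](=O)[O-])cc1)c1ccccn1`: 140 nM

All three values come from a functional assay on T98G cells (Homo sapiens) for cytotoxicity, read by MTT assay, with a stated time of 48 h; on this read-out higher numbers stand for weaker inhibition and lower numbers for stronger inhibition. Compound 1 stands level with compound 2, and the two share the lowest number of the three, while compound 3 sits higher. The next compound is compound 4 `C/C(=N\NC(=S)Nc1cccc([N+](=O)[O-])c1)c1ccccn1`, which departs from compound 1 by a single change: nitro in place of fluoro on an aromatic carbon. This puts nitro in place of fluoro on an aromatic carbon, meta to a large group.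

Among the measured compounds shown here, the only measured step, no change at the digits printed from compound 1 to compound 2 (within the scatter), comes with the fact that one of compounds 1 and 2 is drawn with a defined configuration and the other without, at the place where they differ. It leaves the fluoro untouched, so it gives no size for this exchange and only allows compound 1 and compound 2 to be read as one reference point. The nearest guide is compound 3, which also bears a nitro, but at another place on the ring. A rise is therefore expected because nitro-bearing compound 3 gives 140 nM, though the different place leaves its size uncertain. The expected change is a 4.2-fold higher number from compound 1 to compound 4 (0.62 log units; beyond the scatter), in the direction of weaker inhibition. For compound 4 the value is estimated at 50 nM, with an expected range from 12 nM to 200 nM.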

Compound 4, half-maximal inhibitory concentration: 140 nM
For compound 4 the middle estimate is 2.8-fold (0.45 log units) below the measured one; the range from low to high includes it.
By their numbers in this assay, from the lowest: compounds 1 and 2 (each within the scatter of the next); then compounds 3 and 4 (each within the scatter of the next).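

In this assay, putting nitro in place of fluoro on an aromatic carbon, meta to a large group, is a large change at this position: a 12-fold higher number from compound 1 to compound 4 (1.07 log units; beyond the scatter), in the direction of weaker inhibition. Among the compounds shown here, this is the first size measured for the exchange, and it also shows that a nitro at this place does not differ from one at the other place on the ring: compound 3 gives 140 nM and compound 4 gives 140 nM, the same printed value, although the two are also drawn differently at the double bond. Nothing given here accounts for the rise in the number from fluoro to nitro.

The compounds shown leave open how an amine, a methoxy group or a nitrile at this same place would compare with fluoro and nitro in this assay. They also leave open whether a fluoro moved to the place where compound 3 carries its nitro would keep the low number seen for compound 1, or whether that place follows the nitro result instead.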